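The source may report more compounds than this note shows. Statements on the series, on what has been measured and on what is new or still open speak of the compounds shown alone.

Working notes on the series

The shared core carries a variable aryl group on a double-bonded chain carbon bound to a double-bonded ring carbon. Three members have been measured in a functional assay on A549 cells (Homo sapiens) for inhibition, read by MTT assay, with a stated time of 72 h; a higher number here means a weaker inhibitor, a lower number a stronger inhibitor. Compound 1 `CCOC(=O)C1=C(Nc2ccccc2)S/C(=C\c2ccccc2O)C1=O` gives 16900 nM in this assay and has the lowest number of the three. Compound 2 `CCOC(=O)C1=C(Nc2ccccc2)S/C(=C\c2cc(OC)c(O)c(OC)c2)C1=O` gives 19200 nM in this assay, which lies within the scatter of compound 1, so the two are read as indistinguishable. Compound 3 `CCOC(=O)C1=C(Nc2ccccc2Br)S/C(=C\c2ccc[nH]2)C1=O` gives 43200 nM in this assay, a number beyond the scatter above compound 1; compound 3 also differs from compound 1 at the anilino ring, so the two changes cannot be separated.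

The next member, compound 4 `CCOC(=O)C1=C(Nc2ccccc2)S/C(=C\c2cc3ncccc3[nH]2)C1=O`, differs from compound 1 in one place: a group of 9 heavy atoms (7 carbon, 2 nitrogen; one five-membered aromatic ring with 1 hetero atom, one six-membered aromatic ring with 1 hetero atom) in place of a group of 7 heavy atoms (6 carbon, 1 oxygen; one six-membered aromatic ring of carbon only), on a double-bonded chain carbon bound to a double-bonded ring carbon. For the measured compounds named here, no measured pair isolates this kind of change, and the only other heteroaromatic member, compound 3, carries a second change as well. The expectation is therefore a modest step toward a weaker inhibitor, or none beyond the scatter, with a 1.3-fold higher number from compound 1 to compound 4 (0.11 log units; within the scatter) as the estimated step from compound 1 to compound 4 in this assay. Compound 4 is expected to give about 22000 nM in this assay, within a range from 8000 nM to 55000 nM.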

Compound 4, half-maximal inhibitory concentration: 13600 nM
Beside the measured number, compound 4's estimate is 1.6-fold (0.21 log units) above it; low and high end bracket the measured number.
By their numbers in this assay, from the lowest: compounds 4, 1 and 2 (each within the scatter of the next); then compound 3.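

For the compounds shown here, at the double-bonded chain carbon bound to a double-bonded ring carbon, replacing 2-hydroxyphenyl with the group of 9 heavy atoms, which carries one five-membered and one six-membered aromatic ring, gives a 1.2-fold lower number from compound 1 to compound 4 (0.09 log units; within the scatter) in this assay; this is the first step that isolates a change at this place. The read-out therefore tolerates this exchange of a carbon-only aromatic ring for a group with two nitrogen-containing aromatic rings, with the hydrogen-bond donor and acceptor counts the same on both sides of the step. Nothing at hand bears on why the two groups read alike.

The compounds shown still do not separate the bromine on the anilino ring of compound 3 from the group at the chain carbon. Also open, on these data alone, is how a cyclohexyl group at this place, or a carboxylic acid or an amide in place of the ethyl ester, would read in this assay, and whether any change gives a number beyond the scatter from compound 1 in the lower direction.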